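A few compounds are considered here, and "the series" means these few. Any claim that something is new, unique, unknown or untested is made for them only; others in the source may bear on it.

In an assay on RBL-1 cells for inhibition of Polyunsaturated fatty acid 5-lipoxygenase (Rattus norvegicus) (on this read-out lower numbers stand for stronger inhibition and higher numbers for weaker inhibition), three compounds have been measured. Compound 1 `O=C1NCCN(c2cccc(OCc3ccccc3)c2)N1` gives 1100 nM. Compound 2 `CCC1CN(c2ccccc2)NC(=O)N1` gives 6900 nM, and compound 3 `Cc1cccc(N2CC(C)NC(=O)N2)c1` gives 19000 nM. Among these three numbers, compound 2 stands second highest: its value lies beyond the usual scatter from the value of compound 3, which is higher, and further still from the value of compound 1, which is lower and marks the strongest inhibition seen so far.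

Compound 4 `O=C1NC(CO)CN(c2ccccc2)N1` has not yet been measured in this assay. It differs from compound 2 in one place: hydroxy in place of methyl on a saturated chain carbon bound to a saturated ring carbon. Taken one bond further out, the same change reads ethyl to hydroxymethyl. Among the measured compounds shown here, no measured pair shows what this kind of exchange does on this core, so the expectation rests on compound 2 alone. The step is expected to be small, from compound 2 to compound 4 a 1.3-fold higher number from compound 2 to compound 4 (0.12 log units; within the scatter), and it may well fall within the scatter of repeated measurements. Compound 4 is therefore estimated at 9000 nM, with a range from 3000 nM to 30000 nM.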

Compound 4, half-maximal inhibitory concentration: 40000 nM
Compound 4: middle estimate off by 4.4-fold (0.65 log units), on the low side, outside the stated range (above it).
By their numbers in this assay, from the lowest: compound 1; then compound 2; then compound 3; then compound 4.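

In this assay, hydroxy in place of methyl on a saturated chain carbon bound to a saturated ring carbon, which also reads as ethyl to hydroxymethyl, gives a 5.8-fold higher number from compound 2 to compound 4 (0.76 log units; beyond the scatter) and so clearly weaker inhibition. The earlier compounds shown here could not show this, as none of them differ from one another in one place only: this position responds to the exchange of a single heavy atom. Nothing measured here says why the number rises.

From the compounds shown here alone, it remains open whether other groups at this position, such as aminomethyl, methoxymethyl or a longer chain like propyl, would weaken inhibition in the same way. Going by these compounds, this is also a single step on one core, so whether ethyl to hydroxymethyl acts alike on the core of compound 1 stays unknown.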